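The source may hold more compounds than are shown below. What is called first, only, known or untested is meant among the compounds shown, and "the series" means these compounds.

Compound 1 `N#Cc1cccc(-c2ccc(CN(CC(=O)Nc3cc(Cl)cc(Cl)c3)C(=O)CN3CCCC3)cc2)c1` gives > 3000 nM in a functional assay for antagonist activity at melanin-concentrating hormone receptor 2 (Homo sapiens) (a lower number here means a stronger inhibitor, a higher number a weaker inhibitor), which is a limit of the assay and not a number.
Compound 2 `N#Cc1cccc(-c2ccc(CN(CC(=O)Nc3cc(Cl)cc(Cl)c3)C(=O)CN3CC[C@@H](O)C3)cc2)c1` gives > 3000 nM in this assay, again only a limit.

Compound 2 therefore stands only at the limit, as do both values shown (the limit of > 3000 nM in this assay, at which 2 of the 2 values shown sit). Among the measured compounds shown here, the one measured step, a step that the two limits leave unreadable from compound 1 to compound 2, is unreadable: both of its ends are limits. Compound 3 `N#Cc1cccc(-c2ccc(CN(CC(=O)Nc3cc(Cl)cc(Cl)c3)C(=O)CN3CC[C@H](O)C3)cc2)c1` differs from compound 2 only in configuration: the two compounds have the same atoms and bonds and differ only in configuration as drawn: 1 of 1 stereo elements differ; a stereocentre at a saturated ring carbon is drawn R in compound 2 and S in compound 3. For the measured compounds named here, no measured step bears on this change, so neither direction nor size can be read from the data. Compound 3 is expected to stay at or near the limit, with an estimated step that the limit leaves unreadable from compound 2 to compound 3 and an estimated value of 6000 nM, ranging from 3000 nM to 20000 nM.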

Compound 3, inhibition constant: > 3000 nM
Compound 3: a limit, no number; the forecaster's own chance of this, stated with the estimate: 85%; the middle value lies beyond the limit too.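

In this assay, among the compounds shown here, compound 3 gives > 3000 nM, again a limit and not a number, so no step among compound 1, compound 2 and compound 3 can be read. On these data alone, whether the hydroxy group or its configuration affects inhibition at all remains open.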